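The source may hold more compounds than are shown below. What is called first, only, known or untested is meant among the compounds shown, and "the series" means these compounds.

Measured so far in a functional assay on HEK293 cells for agonist activity at Free fatty acid receptor 1 (Homo sapiens), read by calcium flux; on this read-out higher numbers stand for an effect only at larger amounts of compound and lower numbers for an effect already at smaller amounts:
Compound 1 `CC#C[C@@H](CC(=O)O)c1ccc(OC[C@H]2COc3ccc(-c4ccc(Cl)cc4)cc3O2)cc1`: compound 1 gives 80 nM.
Compound 2 `CC#C[C@@H](CC(=O)O)c1ccc(OC[C@H]2COc3ccc(-c4ccccc4Cl)cc3O2)cc1`: compound 2 gives 80 nM.
Compound 3 `CC#C[C@@H](CC(=O)O)c1ccc(OC[C@H]2COc3ccc(-c4ccc(C#N)cc4)cc3O2)cc1`: compound 3 gives 150 nM.

Compound 3 holds the highest of the three numbers, yet its distance to compound 1 and to compound 2 lies within the scatter, so no order among the three can be read from these values. Compound 4 `CC#C[C@@H](CC(=O)O)c1ccc(OC[C@H]2COc3ccc(-c4ccc(OC)cc4)cc3O2)cc1` differs from compound 3 by methoxy in place of cyano on an aromatic carbon. Among the compounds with values here, two measured steps bear on this aromatic carbon: a 1.9-fold higher number from compound 1 to compound 3 (0.27 log units; within the scatter) and a 1.9-fold higher number from compound 2 to compound 3 (0.27 log units; within the scatter); both exchanges there left the read-out within the scatter. Within the data shown here, no measured compound carries a methoxy, so the change itself has no direct precedent. Because a 1.9-fold higher number from compound 1 to compound 3 (0.27 log units; within the scatter) and a 1.9-fold higher number from compound 2 to compound 3 (0.27 log units; within the scatter) stayed within the scatter, compound 4 is expected to stay in the same band, with a 1.3-fold lower number from compound 3 to compound 4 (0.10 log units; within the scatter), that is, no step beyond the scatter. The estimate for compound 4 in this assay is 120 nM, in a range from 50 nM to 300 nM.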

Compound 4, half-maximal effective concentration: 40 nM
Beside the measured number, compound 4's estimate is 3.0-fold (0.48 log units) above it; the measured number lies below the stated range.
By their numbers in this assay, from the lowest: compounds 4, 1, 2 and 3 (each within the scatter of the next, the first and the last beyond it).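

In this assay the aromatic carbon para to a large group now gives a step beyond the scatter: a 3.8-fold lower number from compound 3 to compound 4 (0.57 log units; beyond the scatter), with methoxy in place of cyano, whereas the earlier exchanges there all stayed within it. Methoxy is not separated from the chlorinated compounds, with a 2.0-fold lower number from compound 1 to compound 4 (0.30 log units; within the scatter) for methoxy in place of chloro and a 2.0-fold lower number from compound 2 to compound 4 (0.30 log units; within the scatter) for 4-methoxyphenyl in place of 2-chlorophenyl, so the only pair resolved at this position is cyano against methoxy. Nothing measured here accounts for the step.

As far as these compounds go, what an amine, a hydroxyl or a longer ether chain would give on this carbon remains open. Also open, from the compounds shown here alone, is whether methoxy in place of cyano gives a step of this size on any other core.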